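This account rests on a few compounds, and the source may have more. Where it says the series, first, only, none or still open, it means among the compounds named here.

Working notes on the series

The common core is the amine of compound 1 `CN(CC1=CC[C@H]2C[C@@H]1C2(C)C)Cc1ccccc1`, which in an assay on HEK293 cells for displacement of a labelled ligand from C-X-C chemokine receptor type 3 (Homo sapiens) (a lower number here means a stronger inhibitor, a higher number a weaker inhibitor), gives 15800 nM. Compound 2 `CN(CC1=CC[C@H]2C[C@@H]1C2(C)C)Cc1ccc(-c2ccccc2)cc1` carries a phenyl in place of hydrogen on an aromatic carbon, and in this assay compound 2 gives 3160 nM, a change of a 5.0-fold lower number from compound 1 to compound 2 (0.70 log units; beyond the scatter). Compound 3 `CN(CC1=CC[C@H]2C[C@@H]1C2(C)C)Cc1ccc(-c2cccc(Cl)c2)cc1` carries a 3-chlorophenyl instead, and in this assay compound 3 gives 3980 nM. Against the shared benzyl compound 1 this is a 4.0-fold lower number from compound 1 to compound 3 (0.60 log units; beyond the scatter); against compound 2 it is a 1.3-fold higher number from compound 2 to compound 3 (0.10 log units; within the scatter). Compound 3 thus sits with the second highest of the three numbers, closest to compound 2 and farthest from compound 1.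

Compound 4 `CN(CC1=CC[C@H]2C[C@@H]1C2(C)C)Cc1ccc(-c2ccc(Cl)cc2)cc1` differs from compound 3 only in where the chlorine sits: 4-chlorophenyl in place of 3-chlorophenyl on an aromatic carbon. For the measured compounds named here, the one measured step that bears on a chlorine at this part of the molecule is a 1.3-fold higher number from compound 2 to compound 3 (0.10 log units; within the scatter), which stayed within the scatter. Going by the values given here, no measured pair shows the move of the chlorine itself. The expectation in this assay is therefore no step beyond the scatter, i.e. an estimated 1.1-fold lower number from compound 3 to compound 4 (0.06 log units; within the scatter). Compound 4 is expected at 3500 nM, within a range of 1400 nM to 9000 nM.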

Compound 4, inhibition constant: > 316 nM
Compound 4 was reported as a limit; the forecaster's own chance of this, stated with the estimate: 5%; the middle value lies beyond the limit too.
By their numbers in this assay, from the lowest: compounds 2 and 3 (each within the scatter of the next); then compound 1.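

In this assay compound 4 gives > 316 nM, which is a limit and not a number, so the steps to compound 4 from compound 1, compound 2 and compound 3 cannot be read. The compounds shown leave open where compound 4 stands among them, and whether 4-chlorophenyl in place of 3-chlorophenyl changes the number at all.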